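A few compounds are considered here, and "the series" means these few. Any claim that something is new, unique, unknown or untested is made for them only; others in the source may bear on it.

Of the compounds shown here, three built on the same core have so far been measured in a functional assay on C8166 cells (Homo sapiens) for cytotoxicity, read by MTT assay; a lower number here means that less compound is tolerated, a higher number that more compound is tolerated. Compound 2 `Cc1cc(C)cc(C(=O)Nc2cc(Cl)ccc2OCC(=O)Nc2ccc(S(N)(=O)=O)cc2C)c1` gives 36500 nM, the lowest number of the three, though its gap to compound 1 lies within the scatter. Compound 1 `Cc1cc(S(N)(=O)=O)ccc1NC(=O)COc1ccc(Cl)cc1NC(=O)c1ccccc1[N+](=O)[O-]` gives 54800 nM, and compound 3 `Cc1cc(S(N)(=O)=O)ccc1NC(=O)COc1ccc(Cl)cc1NC(=O)/C=C/c1ccccc1` gives 163000 nM. Within the data shown here, the steps of a 1.5-fold lower number from compound 1 to compound 2 (0.18 log units; within the scatter) and a 4.5-fold higher number from compound 2 to compound 3 (0.65 log units; beyond the scatter) show how far exchanging the group on the carbonyl carbon has moved the number so far. Compound 4 `Cc1cc(S(N)(=O)=O)ccc1NC(=O)COc1ccc(Cl)cc1NC(=O)c1ccc2ccccc2c1` differs from compound 2 by naphthalen-2-yl in place of 3,5-dimethylphenyl on a carbonyl carbon. Among the measured compounds shown here, both measured exchanges at this carbonyl bear on it, and neither was large; no measured compound shows what a second fused ring does here. Compound 4 is therefore expected to give roughly 40000 nM, within 15000 nM to 110000 nM. The expected step is a 1.1-fold higher number from compound 2 to compound 4 (0.04 log units; within the scatter), not beyond the scatter.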

Compound 4, half-maximal cytotoxic concentration: 37600 nM
The estimate for compound 4 lay 1.1-fold (0.03 log units) above the measured number; the measured number falls inside the stated range.
By their numbers in this assay, from the lowest: compounds 2, 4 and 1 (each within the scatter of the next); then compound 3.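

In this assay, a second fused ring on the carbonyl carbon changes nothing that can be told from the scatter: the data show a 1.0-fold higher number from compound 2 to compound 4 (0.01 log units; within the scatter) and a 1.5-fold lower number from compound 1 to compound 4 (0.16 log units; within the scatter), so the groups of compound 1, compound 2 and compound 4 cannot be separated here. Only the 2-phenylethenyl of compound 3 stands apart, with a 4.3-fold lower number from compound 3 to compound 4 (0.64 log units; beyond the scatter) on going to naphthalen-2-yl. No evidence shown accounts for this pattern. Still open, as far as these compounds go, is whether a carboxylic acid, an amine or a longer chain in this place would stand with compound 3 or with the other three.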